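The compounds below may be only part of what the source reports. "The series", "measured", "known", "first", "only" and "open" are said of these compounds alone.

Working notes on the series, entry for the step from compound 2 to compound 3.

Compound 2 is `COCc1ncc2cnnc(NCCN(C)C)n12`. In a functional assay for inhibition, with Homo sapiens as the target (a lower number here means a stronger inhibitor, a higher number a weaker inhibitor), compound 2 gives > 48000 nM, which is a limit of the assay rather than a number. Compound 1 is `CNc1nncc2cncn12`, the parent core with the short methylamino side chain. In this assay compound 1 gives > 48000 nM, again a limit and not a measured value. Compound 2 therefore stands nowhere in particular on the numbers: everything shown is a limit, and the picture is the limit of > 48000 nM in this assay, at which 2 of the 2 values shown sit. Going by the values given here, no step between measured compounds can be drawn, so the size of any change is unknown.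

Compound 3 is `CN(C)CCNc1nncc2cncn12`. The change from compound 2 is hydrogen in place of methoxymethyl on an aromatic carbon; the dimethylaminoethyl side chain of compound 2 is kept on the core of compound 1. Both neighbours sit at the limit, and nothing here points to either direction beyond the scatter. The step that the limit leaves unreadable from compound 2 to compound 3 is expected to be none that can be seen. For compound 3 the value in this assay is estimated at 60000 nM, within 20000 nM to 200000 nM, most likely reported as a limit once more.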

Compound 3, half-maximal inhibitory concentration: > 48000 nM
Compound 3 was reported as a limit (the forecaster's own chance of this, stated with the estimate: 85%); the middle value lies beyond the limit too.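

In this assay compound 3 gives > 48000 nM, a limit of the assay and not a number. The steps from compound 1 and compound 2 to compound 3 cannot be read. The compounds shown leave open whether methoxymethyl or the dimethylaminoethyl side chain changes inhibition at all, and the picture remains: the limit of > 48000 nM in this assay, at which 3 of the 3 values shown sit.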